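The compounds below may be only part of what the source reports. "The series", "measured", "known", "first", "only" and "open" are said of these compounds alone.

Compound 1 `O=C1Nc2ccccc2/C1=C/c1ccc(-c2cn(-c3ccc(F)cc3)nn2)cc1`: 14700 nM
Compound 2 `O=C1Nc2ccccc2/C1=C/c1ccc(-c2cn(-c3ccc(Cl)cc3)nn2)cc1`: 18200 nM

Going by the values given here, in an ADME assay on HUVEC cells (Homo sapiens) for inhibition, read by CCK-8 assay, with a stated time of 24 h, in the presence of a further agent that is not named here (a higher number here means a weaker inhibitor, a lower number a stronger inhibitor), compound 2 stands level with the only other measured compound. Among the compounds with values here, the one measured step is a 1.2-fold higher number from compound 1 to compound 2 (0.09 log units; within the scatter), for chloro in place of fluoro on an aromatic carbon. Compound 3 `N#Cc1ccccc1-n1cc(-c2ccc(/C=C3\C(=O)Nc4ccccc43)cc2)nn1` carries a different change, 2-cyanophenyl in place of 4-chlorophenyl on an aromatic nitrogen. Within the data shown here, that small step bears on it only loosely, and no measured step covers this swap. The expected step is a 1.0-fold lower number from compound 2 to compound 3 (0.00 log units; within the scatter), so no change beyond the scatter is expected. Compound 3 is estimated at 18000 nM, with an expected range of 8000 nM to 40000 nM.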

Compound 3, half-maximal inhibitory concentration: 19700 nM
Compound 3: middle estimate off by 1.1-fold (0.04 log units), on the low side, and the stated range covers the measured number.
By their numbers in this assay, from the lowest: compounds 1, 2 and 3 (each within the scatter of the next).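

In this assay, 2-cyanophenyl in place of 4-chlorophenyl on the aromatic nitrogen gives a 1.1-fold higher number from compound 2 to compound 3 (0.03 log units; within the scatter) and stays within the scatter. In place of 4-fluorophenyl, it gives a 1.3-fold higher number from compound 1 to compound 3 (0.13 log units; within the scatter) and also stays within the scatter. So, across these three compounds, a halogen on the phenyl ring is not needed to keep the number at this level, and a nitrile serves equally. Still open, as far as these compounds go, is whether a saturated ring, such as cyclohexyl, or a phenyl ring bearing an amine or a carboxylic acid would move the number beyond the scatter. No measured evidence explains why the number holds across these groups.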